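Swapping methyl for methoxy in compound 2

The source may hold more compounds than are shown below. What is called first, only, known or untested is meant among the compounds shown, and "the series" means these compounds.

- compound 1 `COc1ccc(CN2CCC(NC(=O)C(C)(C)CCCOc3cc(C)ccc3C)CC2)cc1` gives 4150 nM
- compound 2 `Cc1ccc(CN2CCC(NC(=O)C(C)(C)Oc3ccc(C(=O)c4ccc(Cl)cc4)cc3)CC2)cc1` gives 8560 nM

In a functional assay on RAW264.7 cells (Mus musculus) for inhibition, read by polymerase chain reaction, with stated times of 12 h and 6 h (on this read-out higher numbers stand for weaker inhibition and lower numbers for stronger inhibition), compound 2 has the higher of the two numbers, 8560 nM, a gap to compound 1 that lies beyond the scatter. Compound 3 `COc1ccc(CN2CCC(NC(=O)C(C)(C)Oc3ccc(C(=O)c4ccc(Cl)cc4)cc3)CC2)cc1` has methoxy in place of methyl on an aromatic carbon, para to a large group (methoxy in place of methyl on an aromatic carbon). Among the compounds with values here, no measured pair shows this change alone, so no step beyond the scatter is expected in this assay. Compound 1 also carries 4-methoxybenzyl and gives 4150 nM, but it differs elsewhere too, which supports only a slight lean towards a lower number. The estimated step of a 1.2-fold lower number from compound 2 to compound 3 (0.09 log units; within the scatter) is small. Compound 3 is estimated at 7000 nM (expected range 3000 nM to 16000 nM).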

Compound 3, half-maximal inhibitory concentration: 4570 nM
Compound 3: the middle estimate sits 1.5-fold (0.19 log units) above what was measured, and the stated range covers the measured number.
By their numbers in this assay, from the lowest: compounds 1, 3 and 2 (each within the scatter of the next, the first and the last beyond it).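

Within the data shown here, compound 2 and compound 3 form the first pair that differs in one place only, so the effect of this change can now be read by itself. In this assay, methoxy in place of methyl, para to a large group, gives a 1.9-fold lower number from compound 2 to compound 3 (0.27 log units; within the scatter), so the two groups cannot be told apart at this position. Nothing available explains this result. As far as these compounds go, it remains open whether an amine or a longer chain such as butoxy at this position would shift the number beyond the scatter. From the compounds shown here alone, whether the same swap behaves alike on the core of compound 1 is also open.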